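Removing one fluoro from the difluorobenzyl group of compound 3

A few compounds are considered here, and "the series" means these few. Any claim that something is new, unique, unknown or untested is made for them only; others in the source may bear on it.

Measured compounds:
Compound 1 `CCOC(=O)/C(O)=C/C(=O)c1cn(Cc2cc(F)c(F)c(F)c2)c2cccc(OC)c12` gives 33400 nM in an ADME assay on MT4 cells (Homo sapiens) for cytotoxicity, read by MTT assay; a lower number here means that less compound is tolerated, a higher number that more compound is tolerated.
Compound 2 `CCOC(=O)/C(O)=C/C(=O)c1cn(Cc2ccc(F)c(F)c2)c2cccc(OC)c12` gives 125000 nM in this assay.
Compound 3 `CCOC(=O)/C(O)=C/C(=O)c1cn(Cc2cc(F)cc(F)c2)c2cccc(OC)c12` gives 34700 nM in this assay.

Compound 3 stands second highest of the three numbers. Its nearest neighbour is compound 1, with a 1.0-fold higher number from compound 1 to compound 3 (0.02 log units; within the scatter) between them, a gap within the scatter. Compound 2 lies furthest away: the step is a 3.6-fold lower number from compound 2 to compound 3 (0.56 log units; beyond the scatter).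

Compound 4 `CCOC(=O)/C(O)=C/C(=O)c1cn(Cc2cccc(F)c2)c2cccc(OC)c12` differs from compound 3 by a single change: hydrogen in place of fluoro on an aromatic carbon. Two earlier steps also remove a fluoro from this ring. One of them, a 1.0-fold higher number from compound 1 to compound 3 (0.02 log units; within the scatter), stayed within the scatter. The other, a 3.7-fold higher number from compound 1 to compound 2 (0.57 log units; beyond the scatter), gave a modest rise, and there the fluoro removed was likewise meta to a remaining fluoro group. The bearing steps therefore point either to no change or to a modest rise in this assay.

Compound 4 is expected to give about 60000 nM, with a range from 25000 nM to 150000 nM; the step from compound 3 is estimated as a 1.7-fold higher number from compound 3 to compound 4 (0.24 log units; within the scatter).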

Compound 4, half-maximal cytotoxic concentration: 63200 nM
Compound 4: the middle estimate sits 1.1-fold (0.02 log units) below what was measured; measured number inside the range.
By their numbers in this assay, from the lowest: compounds 1, 3, 4 and 2 (each within the scatter of the next, the first and the last beyond it).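

In this assay, going from the 3,5-difluorobenzyl to the 3-fluorobenzyl group stays within the scatter, a 1.8-fold higher number from compound 3 to compound 4 (0.26 log units; within the scatter), so removing this fluoro, meta to a fluoro group, shows no clear effect here. Compound 4 also lies within the scatter of both trifluoro compound 1 and 3,4-difluoro compound 2, a 1.9-fold higher number from compound 1 to compound 4 (0.28 log units; within the scatter) and a 2.0-fold lower number from compound 2 to compound 4 (0.30 log units; within the scatter), even though compound 1 and compound 2 lie beyond the scatter of each other. The earlier rise on removing a fluoro therefore cannot be told apart from this smaller step: the same change on two cores in this assay, a 3.7-fold higher number (0.57 log units; beyond the scatter) from compound 1 to compound 2 and a 1.8-fold higher number (0.26 log units; within the scatter) from compound 3 to compound 4, 2.1-fold (0.31 log units) apart, within the scatter of two such steps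

On these data alone, what an unsubstituted benzyl group, or a chloro or trifluoromethyl group at this place, would give stays open. So does whether these small steps would hold with a carboxylic acid in place of the ethyl ester.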